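Swapping Pyridine for Phenyl on a Thioether Chain

This account rests on a few compounds, and the source may have more. Where it says the series, first, only, none or still open, it means among the compounds named here.

Of the compounds shown here, two sharing a common core have been measured. Compound 1 `O=c1c2cn(C3COC3)nc2nc(SCc2cccc(F)c2)n1-c1ccccc1` and compound 2 `CC(Sc1nc2c(cnn2C)c(=O)n1-c1ccccc1)c1ccccn1` were tested in a physicochemical assay for solubility, using the shake flask method, in phosphate buffer, with a stated time of 24 h, at pH 7.4; on this read-out higher numbers stand for higher solubility and lower numbers for lower solubility. Compound 1 gives 5000 nM, while compound 2 gives 20000 nM, the higher of the two numbers, and the gap between them lies beyond the usual scatter. Compound 3 `CC(Sc1nc2c(cnn2C)c(=O)n1-c1ccccc1)c1ccccc1` has not yet been measured. It differs from compound 2 in one place: phenyl in place of pyridin-2-yl on a saturated chain carbon bound to a saturated chain carbon and a sulfur. Within the data shown here, no measured pair shows this change, so the expectation rests on the structures alone. A moderate downward step is expected, a 3.3-fold lower number from compound 2 to compound 3 (0.52 log units; beyond the scatter). Compound 3 is expected to give about 6000 nM, within a range from 2000 nM to 20000 nM.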

Compound 3, solubility: 8000 nM
Beside the measured number, compound 3's estimate is 1.3-fold (0.12 log units) below it; low and high end bracket the measured number.
By their numbers in this assay, from the lowest: compounds 1 and 3 (each within the scatter of the next); then compound 2.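

In this assay, replacing pyridin-2-yl with phenyl on the saturated chain carbon gives a 2.5-fold lower number from compound 2 to compound 3 (0.40 log units; beyond the scatter). Among these compounds, this is the first pair here that differs in one place, so the effect of this change can be read with the rest of the molecule held constant. Nothing measured here explains the step.

As far as these compounds go, whether the same swap gives a similar step on the core of compound 1 remains open. So does how an amine or a carboxylic acid on the ring at this position would compare.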